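Removing one cyanophenyl arm from a weak aromatase inhibitor

This account rests on a few compounds, and the source may have more. Where it says the series, first, only, none or still open, it means among the compounds named here.

Measured compounds:
compound 1 `N#Cc1ccc(C(c2ccc(C#N)cc2)n2cc(COc3ccc(Cl)cc3)nn2)cc1`, 16100 nM
compound 2 `N#Cc1ccc(OCc2cn(C(c3ccc(C#N)cc3)c3ccc(C#N)cc3)nn2)cc1`, 4640 nM

In an assay on isolated protein for inhibition of Aromatase (Homo sapiens), read by fluorescence and colorimetric assay, with a stated time of 30 min (on this read-out lower numbers stand for stronger inhibition and higher numbers for weaker inhibition), compound 1 gives the higher of the two numbers; compound 2 sits a 3.5-fold lower number from compound 1 to compound 2 (0.54 log units; beyond the scatter). Compound 3 `N#Cc1ccc(Cn2cc(COc3ccc(Cl)cc3)nn2)cc1` differs from compound 1 by hydrogen in place of 4-cyanophenyl on a saturated chain carbon bound to an aromatic carbon and an aromatic nitrogen. Going by the values given here, neither measured step touches this part of the core, so the only guide is the change itself, and compound 1 already shows a high number in this assay. Compound 3 is expected to be weaker, by a step of about a 2.8-fold higher number from compound 1 to compound 3 (0.45 log units; beyond the scatter). The estimate for compound 3 is 45000 nM, between 12000 nM and 150000 nM.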

Compound 3, half-maximal inhibitory concentration: 3910 nM
Beside the measured number, compound 3's estimate is 12-fold (1.06 log units) above it; measured number below the stated range.
By their numbers in this assay, from the lowest: compounds 3 and 2 (each within the scatter of the next); then compound 1.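

Taking away the 4-cyanophenyl on the saturated chain carbon does not cost inhibition in this assay: with hydrogen in its place, the step is a 4.1-fold lower number from compound 1 to compound 3 (0.61 log units; beyond the scatter). This position therefore does not need this aryl group for activity in this assay, and its removal improves the number of the weak compound 1. No supporting data bear on why this happens. The compounds shown leave open whether a methyl group or an amine on this carbon would match hydrogen. They also leave open whether cyano in place of chloro would lower the number for compound 3.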